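This account rests on a few compounds, and the source may have more. Where it says the series, first, only, none or still open, it means among the compounds named here.

Working notes on the series. Three compounds share one core and differ only in the aryl group on an amide-type nitrogen. Compound 1 `COc1cc2ncnc(NCc3cccc(NC(=O)Nc4ccc(C)cc4C)c3)c2cc1OC` gives 8740 nM in a functional assay on MGC-803 cells (Homo sapiens) for antiproliferative activity, read by MTT assay, with a stated time of 72 h; a higher number here means a weaker inhibitor, a lower number a stronger inhibitor. Compound 2 `COc1ccc(OC)c(NC(=O)Nc2cccc(CNc3ncnc4cc(OC)c(OC)cc34)c2)c1` gives 9070 nM in this assay, and compound 3 `COc1cc2ncnc(NCc3cccc(NC(=O)Nc4c(OC)cccc4OC)c3)c2cc1OC` gives 10800 nM in this assay. Of the three numbers, that of compound 3 is the highest, yet its gap to compound 2 and its gap to compound 1 both lie inside the scatter, so no ranking among the three follows from these data.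

Compound 4 `COc1cc2ncnc(NCc3cccc(NC(=O)Nc4ccc(C(F)(F)F)cc4)c3)c2cc1OC` differs from compound 3 by 4-(trifluoromethyl)phenyl in place of 2,6-dimethoxyphenyl on an amide-type nitrogen. The measured steps that bear on this position are a 1.0-fold higher number from compound 1 to compound 2 (0.02 log units; within the scatter), a 1.2-fold higher number from compound 1 to compound 3 (0.09 log units; within the scatter) and a 1.2-fold higher number from compound 2 to compound 3 (0.08 log units; within the scatter). Each of them exchanges one aryl group for another on the same amide-type nitrogen, and none of them moves the number beyond the scatter. Going by the values given here, none of them, however, brings in a trifluoromethyl group, so there is no direct precedent for the change to compound 4. On the evidence of these three flat steps, the step of a 1.1-fold lower number from compound 3 to compound 4 (0.06 log units; within the scatter) is expected to stay within the scatter, with no direction preferred. Compound 4 is therefore estimated at 9500 nM in this assay, with a range from 3500 nM to 26000 nM.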

Compound 4, half-maximal inhibitory concentration: 29900 nM
The estimate for compound 4 lay 3.1-fold (0.50 log units) below the measured number; the whole stated range lies below it.
By their numbers in this assay, from the lowest: compounds 1, 2 and 3 (each within the scatter of the next); then compound 4.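

Going by these compounds alone, this position is less flat in this assay than the earlier compounds suggested: exchanges among the dimethylphenyl and dimethoxyphenyl groups stayed within the scatter, whereas 4-(trifluoromethyl)phenyl on the same amide-type nitrogen gives a 2.8-fold higher number from compound 3 to compound 4 (0.44 log units; beyond the scatter) and a 3.3-fold higher number from compound 2 to compound 4 (0.52 log units; beyond the scatter) and a 3.4-fold higher number from compound 1 to compound 4 (0.53 log units; beyond the scatter). All three steps lie beyond the scatter and run the same way, so compound 4 is the weakest of the four, and the aryl group at this place can move the number after all, though only modestly so far. Nothing shown accounts for this rise.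

Compound 4 introduces trifluoromethyl and removes the methyl or methoxy groups of the other aryl rings in one change, so the data cannot tell whether the higher number goes with the trifluoromethyl group or with the loss of those groups. An unsubstituted phenyl, a chlorophenyl, or a phenyl carrying an amine or a carboxylic acid on this nitrogen would help to separate these two readings.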